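The compounds below may be only part of what the source reports. "The series", "measured", "known", "first", "only" and "open" are said of these compounds alone.

Of the compounds shown here, three have been measured in a functional assay on T29Kt1 cells (Homo sapiens) for cytotoxicity, read by sulforhodamine B assay, with a stated time of 3 days; a higher number here means a weaker inhibitor, a lower number a stronger inhibitor. There, compound 1 (`O=Cc1cn(Cc2cccc(Cl)c2)c2ccc(F)cc12`) gives 1500 nM, compound 2 (`O=Cc1cn(Cc2ccc(Cl)cc2)c2ccc(F)cc12`) gives 9090 nM, and compound 3 (`OCc1cn(Cc2cccc(F)c2)c2ccccc12`) gives 20 nM. Compound 3 therefore has the lowest of the three numbers, and its distance from each of the other two lies well beyond the scatter of repeated measurements. For the measured compounds named here, these three compounds differ from one another in more than one place, so no measured pair isolates the effect of a single change.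

The next compound to be tested is compound 4 (`OCc1cn(Cc2cccc(Br)c2)c2ccccc12`), which carries bromo in place of fluoro on an aromatic carbon, meta to a large group, with the rest of compound 3 unchanged: bromo in place of fluoro on an aromatic carbon. No measured step among these compounds shows what such an exchange does in this assay. Going by the values given here, the only direct guide is therefore the parent, compound 3 at 20 nM. With so small a change in the count of atoms, no step beyond the scatter is expected in either direction. The expected step is a 1.5-fold higher number from compound 3 to compound 4 (0.18 log units; within the scatter), an estimate that remains uncertain. For compound 4 the estimated value is 30 nM, with an expected range from 8 nM to 150 nM.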

Compound 4, half-maximal inhibitory concentration: 32 nM
Compound 4: middle estimate off by 1.1-fold (0.03 log units), on the low side, within the range that was stated.
By their numbers in this assay, from the lowest: compounds 3 and 4 (each within the scatter of the next); then compound 1; then compound 2.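

In this assay, for the compounds shown here, compound 4 supplies the first comparison in this set that isolates one change, and the exchange of fluoro for bromo gives a 1.6-fold higher number from compound 3 to compound 4 (0.20 log units; within the scatter). At this place, on an aromatic carbon of a six-membered aromatic ring of carbon only and meta to a large group, the two halogens therefore cannot be told apart in this read-out, even though each replaces the other atom for atom and the heavy-atom count stays the same. This is a single exchange at a single position, so it sets no rule for other substituents or other places on the molecule, and nothing available here accounts for the outcome.

On these data alone, whether the same position would keep such a number with a group other than a halogen, such as methoxy, an amine, a carboxylic acid or a longer alkyl chain, remains open. Also open, as far as these compounds go, is what a single change elsewhere on the shared core would do, as compounds 1 and 2 each differ from compounds 3 and 4 in more than one place.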